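The compounds below may be only part of what the source reports. "The series", "measured", "known", "first", "only" and "open" are said of these compounds alone.

Compound 1 `O=C(N/N=C/c1ccncc1)c1cc2cc(Br)ccc2oc1=O` and compound 2 `O=C(N/N=C/c1ccncc1)c1cc2cc([N+](=O)[O-])ccc2oc1=O` share one core, while compound 3 `Cc1noc(NS(=O)(=O)c2ccc(NC(=O)c3cc4cc([N+](=O)[O-])ccc4oc3=O)cc2)c1C` carries a much larger side part. In a functional assay on PANC-1 cells (Homo sapiens) for antiproliferative activity, read by fluorescence and resazurin assay, with a stated time of 48 h (on this read-out higher numbers stand for weaker inhibition and lower numbers for stronger inhibition), compound 1 gives 25700 nM, compound 2 gives 26100 nM, and compound 3 gives 11900 nM. The difference between the core of compound 2 and the core of compound 3 is not broken down here. Within the first pair, the change bromo in place of nitro on an aromatic carbon leads to a 1.0-fold lower number from compound 2 to compound 1 (0.01 log units; within the scatter). Compound 4 `Cc1noc(NS(=O)(=O)c2ccc(NC(=O)c3cc4cc(Br)ccc4oc3=O)cc2)c1C` carries the same change relative to compound 3, namely (bromo in place of nitro on an aromatic carbon), at the same place on the shared ring system. Because a 1.0-fold lower number from compound 2 to compound 1 (0.01 log units; within the scatter) stays within the scatter, the expected step is a 1.0-fold higher number from compound 3 to compound 4 (0.00 log units; within the scatter). In this assay compound 4 is therefore estimated at 12000 nM, with a likely range from 6000 nM to 24000 nM.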

Compound 4, half-maximal inhibitory concentration: 28700 nM
For compound 4 the middle estimate is 2.4-fold (0.38 log units) below the measured one, outside the stated range (above it).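

Putting bromo in place of nitro gives a 2.4-fold higher number from compound 3 to compound 4 (0.38 log units; beyond the scatter) in this assay, so on this larger core the change weakens inhibition by more than the usual scatter. Set beside the same change on the other core, the two steps still cannot be told apart: the same change on two cores in this assay, a 1.0-fold lower number (0.01 log units; within the scatter) from compound 2 to compound 1 and a 2.4-fold higher number (0.38 log units; beyond the scatter) from compound 3 to compound 4, 2.4-fold (0.39 log units) apart, within the scatter of two such steps. This fits a change that carries over between the two cores, but two pairs do not prove that it does, and they do not show that the core alters its effect.

The compounds shown leave open how an amine or a carboxylic acid on this aromatic carbon would behave on either core. They also leave open what the same change would do on a third core.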